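The source may report more compounds than this note shows. Statements on the series, on what has been measured and on what is new or still open speak of the compounds shown alone.

Measured in a physicochemical assay for solubility; a higher number here means a more soluble compound, a lower number a less soluble compound:
- compound 1 `CNC(=O)c1cc(C(=O)N[C@H]2[C@@H]3COC[C@@H]32)cc2c1OC[C@@]2(CO)c1ccccc1`: >= 202 ug/mL
- compound 2 `CNC(=O)c1cc(C(=O)N[C@H]2C[C@@H]2C)cc2c1OC[C@@]2(C)c1ccccc1`: 3 ug/mL

Compound 1 gives >= 202 ug/mL, which is a limit of the assay and not a number. Going by the values given here, that leaves compound 2, at 3 ug/mL, as the only true number so far. Compound 3 `CNC(=O)c1cc(C(=O)N[C@H]2C[C@@H]2C)cc2c1OC[C@@]2(CO)c1ccccc1` differs from compound 2 by one change: hydroxy in place of hydrogen on a saturated chain carbon bound to a saturated ring carbon, turning methyl into hydroxymethyl. Among the compounds with values here, no measured pair shows this change alone. A rise beyond the scatter in this assay is expected, an expectation that leans only on the limit of compound 1 >= 202 ug/mL. The expected change is an 8.3-fold higher number from compound 2 to compound 3 (0.92 log units; beyond the scatter). Compound 3 is estimated at 25 ug/mL, with an expected range of 7 ug/mL to 120 ug/mL.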

Compound 3, solubility: >= 229 ug/mL
Compound 3 gave a limit, no number; the forecaster's own chance of this, stated with the estimate: 8%; middle value at least 9.1-fold (0.96 log units) from the limit.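

In this assay, the change from methyl to hydroxymethyl, on a saturated chain carbon bound to a saturated ring carbon, can now be read alone as an at least 76-fold higher number from compound 2 to compound 3 (1.88 log units; beyond the scatter) with nothing else altered. Compound 3 stands at >= 229 ug/mL and this is a limit of the assay, not a number. The step from compound 1 to compound 3 cannot be read.

As far as these compounds go, how far this rise reaches remains open, with no true number on the hydroxymethyl side. Also open, from the compounds shown here alone, is what an amine or a carboxylic acid would give on this same carbon.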